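Phenyl for Methyl on the Amide of Compound 2

A few compounds are considered here, and "the series" means these few. Any claim that something is new, unique, unknown or untested is made for them only; others in the source may bear on it.

Compound 2 `CC(=O)NC1CCC(CN2CCN(c3cc(=O)c4cc(C(F)(F)F)cc([N+](=O)[O-])c4s3)CC2)CC1` gives 86.8% in an ADME assay on cells (Hepatocyte, Homo sapiens) for metabolic stability, with a stated time of 30 min (on this read-out higher numbers stand for a more stable compound and lower numbers for a less stable compound), the highest of the three numbers measured. Compound 1 `O=c1cc(N2CCN(CC3CCC(O)CC3)CC2)sc2c([N+](=O)[O-])cc(C(F)(F)F)cc12` gives 72.7% in this assay, and compound 3 `O=c1cc(N2CCN(CC3CCCCC3)CC2)sc2c(NO)cc(C(F)(F)F)cc12` gives 19.1%. Among the compounds with values here, the only step measured between close neighbours is a number 14.1 percentage points higher from compound 1 to compound 2 (beyond the scatter). Compound 4 `O=C(NC1CCC(CN2CCN(c3cc(=O)c4cc(C(F)(F)F)cc([N+](=O)[O-])c4s3)CC2)CC1)c1ccccc1` carries phenyl in place of methyl on a carbonyl carbon. Within the data shown here, no measured pair shows this particular change; the step from compound 1 to compound 2 touches the same amide but exchanged a different group, so it offers only a loose guide. A step beyond the scatter is therefore not expected in either direction. The estimate for compound 4 is 80%, within a range from 60% to 95%. This amounts to an expected step of a number 6.8 percentage points lower from compound 2 to compound 4 (within the scatter).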

Compound 4, percent of the compound remaining: 92.9%
Compound 4: middle estimate off by 12.9 percentage points, on the low side, and the stated range covers the measured number.
By their numbers in this assay, from the lowest: compound 3; then compound 1; then compounds 2 and 4 (each within the scatter of the next).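

In this assay, the step is a number 6.1 percentage points higher from compound 2 to compound 4 (within the scatter) for phenyl in place of methyl on a carbonyl carbon, so this amide position carries a single-ring aromatic group as well as a methyl with no change beyond the scatter. The step is a number 20.2 percentage points higher from compound 1 to compound 4 (beyond the scatter) when benzamido replaces hydroxy, which places benzamido, like acetamido, clear of the hydroxy compound. Nothing available here explains either step.
Open, on these data alone, is whether a cyclohexyl or a pyridine ring on the same carbonyl carbon would give a similar number, and whether a plain amine in place of the amide would.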